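A few compounds are considered here, and "the series" means these few. Any claim that something is new, unique, unknown or untested is made for them only; others in the source may bear on it.

Measured in a functional assay on HepG2 cells (Homo sapiens) for inhibition, read by MTT assay, with a stated time of 72 h; a higher number here means a weaker inhibitor, a lower number a stronger inhibitor:
- compound 1 `CC(C)=CCC/C(C)=C/C[C@@H]1C[C@]2(CC=C(C)C)C(=O)[C@@](CC=C(C)C)(C(=O)C(C(=O)c3ccc(OCC(=O)O)c(OCC(=O)O)c3)=C2O)[C@@]1(C)CCC=C(C)C`: > 20000 nM
- compound 2 `CC(C)=CCC/C(C)=C/C[C@@H]1C[C@]2(CC=C(C)C)C(=O)[C@@](CC=C(C)C)(C(=O)C(OC(=O)c3ccc(O)c(O)c3)=C2O)[C@@]1(C)CCC=C(C)C`: > 20000 nM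

Compound 2 stands at > 20000 nM, which is a limit of the assay and not a number.

Compound 1 stands at > 20000 nM, which is also a limit.

Taken together, the series so far reads as the limit of > 20000 nM in this assay, at which 2 of the 2 values shown sit. Neither compound gives a number, so no ranking can be drawn between them.

The next compound is compound 3 `CC(C)=CCC/C(C)=C/C[C@@H]1C[C@]2(CC=C(C)C)C(=O)[C@@](CC=C(C)C)(C(=O)C(Cc3ccc(O)c(O)c3)=C2O)[C@@]1(C)CCC=C(C)C`, which carries 3,4-dihydroxybenzyl in place of ((3,4-dihydroxyphenyl)carbonyl)oxy on a double-bonded ring carbon of the shared core. The counted difference is 3,4-dihydroxybenzyl in place of ((3,4-dihydroxyphenyl)carbonyl)oxy on a double-bonded ring carbon.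

Among the compounds with values here, no measured step is available to size this change, so any expectation is loose. A small move towards stronger inhibition in this assay is expected, with a reading that stays close to the limit held by compound 2. The expected change is an at least 1.3-fold lower number from compound 2 to compound 3 (0.12 log units; that floor lies within the scatter), and this remains an estimate. A further report of a limit alone is quite possible.

For compound 3 the estimated value is 15000 nM, with an expected range from 5000 nM to 30000 nM.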

Compound 3, half-maximal inhibitory concentration: > 20000 nM
Compound 3 gave a limit, no number (the forecaster's own chance of this, stated with the estimate: 50%); middle value at least 1.3-fold (0.12 log units) from the limit.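

Compound 3 gives > 20000 nM, which is a limit and not a number. With compound 2 also at a limit, no step can be read between compound 2 and compound 3: the limit of > 20000 nM in this assay, at which 3 of the 3 values shown sit.

The compounds shown leave open how 3,4-dihydroxybenzyl and ((3,4-dihydroxyphenyl)carbonyl)oxy on the double-bonded ring carbon compare, and how any of the three compounds ranks.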